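Adding a second methyl to compound 2

The compounds below may be only part of what the source reports. "The series", "measured", "known", "first", "only" and "open" are said of these compounds alone.

In a functional assay on M21 cells (Homo sapiens) for inhibition, read by sulforhodamine B assay, with a stated time of 48 h (a higher number here means a weaker inhibitor of growth, a lower number a stronger inhibitor of growth), compound 1 (`CC(C)(C)c1ccc(NC(=O)NC(=O)CCl)cc1`) gives 1100 nM and compound 2 (`Cc1ccc(NC(=O)NC(=O)CCl)cc1`) gives 4900 nM. Compound 2 therefore holds the higher of the two numbers, making it the weaker inhibitor of growth of this measured pair. Compound 3 (`Cc1ccc(NC(=O)NC(=O)CCl)cc1C`) differs from compound 2 by methyl in place of hydrogen on an aromatic carbon. For the measured compounds named here, one measured step bears on this change: a 4.5-fold higher number from compound 1 to compound 2 (0.65 log units; beyond the scatter), with methyl in place of tert-butyl on an aromatic carbon. It is only a loose guide, since it replaces an existing group, whereas the new methyl replaces hydrogen. It points modestly towards a lower number with the larger group. A small move in that direction is expected, namely a 1.5-fold lower number from compound 2 to compound 3 (0.19 log units; within the scatter), and it may not clear the scatter. The estimate for compound 3 is 3200 nM, with an expected range of 1400 nM to 7000 nM.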

Compound 3, concentration for 50% growth inhibition: 4300 nM
For compound 3 the middle estimate is 1.3-fold (0.13 log units) below the measured one; the range from low to high includes it.
By their numbers in this assay, from the lowest: compound 1; then compounds 3 and 2 (each within the scatter of the next).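

In this assay, methyl in place of hydrogen on the aromatic carbon ortho to a methyl group and meta to a group of 8 heavy atoms gives a 1.1-fold lower number from compound 2 to compound 3 (0.06 log units; within the scatter), so this added methyl leaves the number within the scatter. The earlier compounds shown here showed only a change at the site of the existing group, a 4.5-fold higher number from compound 1 to compound 2 (0.65 log units; beyond the scatter), and that larger step does not carry over to this new position. No measurement at hand gives a reason for this result.

Open, as far as these compounds go, is whether a group other than methyl at this position, such as a methoxy group, an amine or a carboxylic acid, would move the number beyond the scatter. Also open, from the compounds shown here alone, is whether the added methyl would give the same result with tert-butyl as the existing group, as in the core of compound 1.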